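The compounds below may be only part of what the source reports. "The series", "measured", "known", "first", "only" and "open" are said of these compounds alone.

Compound 1 `C[C@@H](NC(=O)C1(NC(=O)c2cncc(Cl)n2)CC1)c1ccc(-n2nc(Cl)c3ccccc32)cc1F`: an in vivo ADME assay on the whole organism (strain Sprague-Dawley) for metabolic stability, with Rattus norvegicus as the target (on this read-out lower numbers stand for a shorter-lived compound and higher numbers for a longer-lived compound), 1.6 h
Compound 2 `COc1cncc(C(=O)NC2(C(=O)N[C@H](C)c3ccc(-n4nc(Cl)c5ccccc54)cc3F)CC2)c1`: this assay 0.7 h

Of the two measured compounds, compound 2 gives the lowest number in this assay, and its nearest neighbour is compound 1, which gives the higher number. Among the compounds with values here, the single step with one change connects them: a 2.3-fold lower number from compound 1 to compound 2 (0.36 log units; beyond the scatter), where a methoxypyridinyl group takes the place of a chloropyrazinyl group on a carbonyl carbon.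

Compound 3 `COc1cc(C(=O)NC2(C(=O)N[C@H](C)c3ccc(-n4nc(Cl)c5ccccc54)cc3F)CC2)on1` has not yet been measured in this assay. It differs from compound 2 in one place: 3-methoxy-1,2-oxazol-5-yl in place of 5-methoxypyridin-3-yl on a carbonyl carbon. Within the data shown here, the only measured step that bears on this change is the one from compound 1 to compound 2, itself an exchange of an aromatic group on the same carbonyl carbon, and it was modest. Among the measured compounds shown here, no measured pair shows an oxazolyl group entering at this place, so the direction is open. On this basis a step of about the size a 1.1-fold higher number from compound 2 to compound 3 (0.06 log units; within the scatter) is expected, that is, nothing clearly beyond the scatter. Compound 3 is therefore estimated at 0.8 h in this assay, within a range from 0.4 h to 1.8 h.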

Compound 3, half-life: 3.1 h
For compound 3 the middle estimate is 3.9-fold (0.59 log units) below the measured one; the measured number lies above the stated range.
By their numbers in this assay, from the lowest: compound 2; then compounds 1 and 3 (each within the scatter of the next).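

Within the data shown here, the exchange on the carbonyl carbon is not confined to shortening the half-life in this assay: the ring that enters here moves the number upward (a 4.4-fold higher number from compound 2 to compound 3 (0.65 log units; beyond the scatter)), the opposite direction to the only earlier step at this place. Compound 2 and compound 3 both carry a methoxy group, so a methoxy-bearing aromatic group at this place does not by itself fix a short half-life; the two differ in the ring that carries it, six-membered with 1 hetero atom in one and five-membered with 2 hetero atoms in the other. Against the chloropyrazine compound the new group shows no separation (a 1.9-fold higher number from compound 1 to compound 3 (0.29 log units; within the scatter)), so 3-methoxy-1,2-oxazol-5-yl and 6-chloropyrazin-2-yl stand level in this read-out. Nothing measured here explains the rise from the pyridine to the oxazole.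

From the compounds shown here alone, it remains open how much of the value of compound 3 depends on the methoxy group itself, a question that the unsubstituted 1,2-oxazol-5-yl ring or an ethoxy or amino group in its stead would address. Whether other five-membered rings on this carbonyl carbon, such as a 1,3-thiazole, behave like the 1,2-oxazole also stays undecided.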